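The compounds below may be only part of what the source reports. "The series", "measured", "known", "first", "only" and "open" are said of these compounds alone.

Going by the values given here, in a functional assay on CCRF-CEM cells (Homo sapiens) for inhibition (on this read-out lower numbers stand for stronger inhibition and higher numbers for weaker inhibition), only two compounds sharing a similar design have been measured so far. Compound 1 `O=C1/C(=C/c2ccc(Cl)cc2)Cc2ccccc21` gives 284000 nM. Compound 2 `O=C1/C(=C/c2ccc(Br)cc2)CCc2ccccc21` returns only a limit of the assay, > 500000 nM, so it has no exact number. The next compound keeps the core of compound 2 and changes one group. Compound 3 `CN(C)c1ccc(/C=C2\CCc3ccccc3C2=O)cc1` carries dimethylamino in place of bromo on an aromatic carbon, para to a large group: dimethylamino in place of bromo on an aromatic carbon. Among the compounds with values here, with no measured step to draw on, the only guide is compound 1 at 284000 nM, which suggests that a number may be reached but gives no reason to expect a large gain. A modest move towards stronger inhibition is therefore expected, an estimated at least 2.5-fold lower number from compound 2 to compound 3 (0.39 log units; beyond the scatter). For compound 3 the estimated value is 200000 nM, with an expected range of 50000 nM to 500000 nM.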

Compound 3, half-maximal inhibitory concentration: 1650 nM
Estimate against measurement, compound 3: 120-fold (2.08 log units) above; the whole stated range lies above it.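

In this assay, the aromatic carbon para to a large group turns out to be a highly responsive place: dimethylamino in place of bromo gives an at least 300-fold lower number from compound 2 to compound 3 (2.48 log units; beyond the scatter). Going by these compounds alone, compound 1 and compound 2 carry a halogen at this place and differ from each other elsewhere as well, so they offered no single-change step and gave no sign that one change here could matter so much. Compound 2 stands at a limit of the assay and not at a number, so the step has a known minimum but no known full size: the limit of > 500000 nM in this assay, at which 1 of the 3 values shown sits.

From the compounds shown here alone, whether this gain is particular to dimethylamino, or would also come with a primary amine, a methoxy group or a morpholine at this place, stays open. Also open, going by these compounds, is whether the same change on the core of compound 1 would give a step of similar size.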